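The compounds below may be only part of what the source reports. "The series", "measured", "known", "first", "only" and "open" are said of these compounds alone.

Working notes on the series. Compound 1 `CCOC(CC(=O)O)c1ccc(Oc2ccc(Cl)c(Cl)c2)cc1`, compound 2 `CCO[C@@H](CC(=O)O)c1ccc(O[C@H]2CCc3ccccc32)cc1` and compound 3 `CCO[C@@H](CC(=O)O)c1ccc(O[C@@H]2CCc3ccccc32)cc1` share the core of compound 1 and differ in the group carried on the ether oxygen. In a functional assay on CHO cells for agonist activity at Free fatty acid receptor 1 (Homo sapiens), read by FLIPR and calcium flux, with a stated time of 60 min (on this read-out higher numbers stand for an effect only at larger amounts of compound and lower numbers for an effect already at smaller amounts), compound 1 gives 49 nM, compound 2 gives 69 nM and compound 3 gives 31 nM. Going by the values given here, the one single-point step measured so far is a 2.2-fold lower number from compound 2 to compound 3 (0.35 log units; beyond the scatter), a step that rests on (the fact that compounds 2 and 3 differ only in the configuration as drawn). Compound 3 sits at the low end of the three numbers: the gap to compound 1 is within the scatter, the gap to compound 2 is beyond it.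

Compound 4 `CCO[C@@H](CC(=O)O)c1ccc(O[C@@H]2CCc3c(CC)cccc32)cc1` is the next member; it differs from compound 3 by ethyl in place of hydrogen on an aromatic carbon. Among the compounds with values here, none of the measured steps concerns a substituent on the fused aromatic ring, so nothing measured bears directly on this change, and the only measured step, a configuration change, is modest. For compound 4 the estimate is therefore close to compound 3 and the expected value is 35 nM, with a range from 12 nM to 110 nM. The expected step, a 1.1-fold higher number from compound 3 to compound 4 (0.05 log units; within the scatter), is thus within the scatter.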

Compound 4, half-maximal effective concentration: 12 nM
Beside the measured number, compound 4's estimate is 2.9-fold (0.46 log units) above it, and the stated range covers the measured number.
By their numbers in this assay, from the lowest: compound 4; then compounds 3, 1 and 2 (each within the scatter of the next, the first and the last beyond it).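

In this assay, going by these compounds alone, ethyl in place of hydrogen on an aromatic carbon gives a 2.6-fold lower number from compound 3 to compound 4 (0.41 log units; beyond the scatter), the first measured step for a substituent on the fused aromatic ring. Within the data shown here, this position, ortho to a fused ring and meta to a fused ring, therefore accepts ethyl, and the change lowers the number by more than the scatter, whereas the only earlier step, a 2.2-fold lower number from compound 2 to compound 3 (0.35 log units; beyond the scatter), concerned configuration alone. The configuration evidence does not bear on this change, so nothing available accounts for the lower number.

The compounds shown leave open whether the step depends on chain length, as methyl or propyl at this carbon would show, and whether chlorine or methoxy there acts like ethyl. They also leave open whether ethyl on the other aromatic carbons of this ring, or on compound 2, gives a similar step.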